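Changing the Chain Amine: Pyrrolidine to 4-Methylpiperidine

The source may hold more compounds than are shown below. What is called first, only, known or untested is meant among the compounds shown, and "the series" means these compounds.

Compound 1 `COc1cc2c(Oc3ccc(NC(=O)c4nn(-c5ccccc5C)c(=O)cc4C)cc3F)ccnc2cc1OCCCN1CCC(C)CC1` gives 1460 nM in a functional assay on A549 cells (Homo sapiens) for inhibition, read by MTT assay, with a stated time of 72 h; on this read-out lower numbers stand for stronger inhibition and higher numbers for weaker inhibition.
Compound 2 `COc1cc2c(Oc3ccc(NC(=O)c4nn(-c5ccccc5C(F)(F)F)c(=O)cc4C)cc3F)ccnc2cc1OCCCN1CCC(C)CC1` gives 160 nM in this assay.
Compound 3 `COc1cc2c(Oc3ccc(NC(=O)c4nn(-c5cccc(F)c5)c(=O)cc4C)cc3F)ccnc2cc1OCCCN1CCCC1` gives 170 nM in this assay.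

Among the three measured numbers, compound 3 stands second highest. Compound 2 is its nearest neighbour, and the two values lie within the scatter of each other, so no order between them can be read. Compound 1 is furthest from compound 3, with a number beyond the scatter higher.

Compound 4 `COc1cc2c(Oc3ccc(NC(=O)c4nn(-c5cccc(F)c5)c(=O)cc4C)cc3F)ccnc2cc1OCCCN1CCC(C)CC1` differs from compound 3 in one place: 4-methylpiperidin-1-yl in place of pyrrolidin-1-yl on a saturated chain carbon, three bonds along the chain from an oxygen on an aromatic ring. Within the data shown here, the only measured single change, a 9.1-fold lower number from compound 1 to compound 2 (0.96 log units; beyond the scatter), concerns the aromatic substituent, not the chain amine, and so does not bear on this step. Among the measured compounds shown here, no measured pair shows the effect of swapping the chain amine on its own, so the step from compound 3 to compound 4 carries no expected direction beyond the scatter. This amounts to an expected no change at the digits printed from compound 3 to compound 4 (within the scatter). Compound 4 is therefore estimated at 170 nM, with a range from 70 nM to 420 nM.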

Compound 4, half-maximal inhibitory concentration: 250 nM
Beside the measured number, compound 4's estimate is 1.5-fold (0.17 log units) below it; the range from low to high includes it.
By their numbers in this assay, from the lowest: compounds 2, 3 and 4 (each within the scatter of the next); then compound 1.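

In this assay, the chain amine change gives a 1.5-fold higher number from compound 3 to compound 4 (0.17 log units; within the scatter), so with 3-fluorophenyl on the aromatic nitrogen, the two amines cannot be told apart. With 4-methylpiperidin-1-yl held fixed, 3-fluorophenyl in place of 2-methylphenyl gives a 5.8-fold lower number from compound 1 to compound 4 (0.77 log units; beyond the scatter), whereas 3-fluorophenyl in place of 2-(trifluoromethyl)phenyl gives a 1.6-fold higher number from compound 2 to compound 4 (0.19 log units; within the scatter), so only the 2-methylphenyl compound stands apart from the other two. No measurement offered here accounts for either the small amine step or the larger aryl step.

As far as these compounds go, whether the amine change stays this small with 2-methylphenyl or 2-(trifluoromethyl)phenyl on the aromatic nitrogen remains open. Also open, from the compounds shown here alone, is how a morpholine or a dimethylamine at the end of the chain, or a shorter chain, would read in this assay.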